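Replacing Nitro with Trifluoromethyl: What to Expect

The source may hold more compounds than are shown below. What is called first, only, known or untested is meant among the compounds shown, and "the series" means these compounds.

Of the compounds shown here, three sharing one core have been tested so far. In a functional assay on SGC-7901 cells (Homo sapiens) for antiproliferative activity, read by MTT assay, with a stated time of 72 h (on this read-out lower numbers stand for stronger inhibition and higher numbers for weaker inhibition), compound 1 `CCOc1ccc(-c2ccc3ncn(-c4cc(OC)c(OC)c(OC)c4)c3c2)cc1` gives 2970 nM while compound 2 `COc1ccc(-c2ccc3ncn(-c4cc(OC)c(OC)c(OC)c4)c3c2)cc1O` gives 44 nM and compound 3 `COc1cc(-n2cnc3ccc(-c4ccc([N+](=O)[O-])cc4)cc32)cc(OC)c1OC` gives 79 nM on the same scale. Compound 3 therefore stands with compound 2 at the low-number end of this small set. There is a 1.8-fold higher number from compound 2 to compound 3 (0.25 log units; within the scatter) and so no real difference there, whereas there is a 38-fold lower number from compound 1 to compound 3 (1.58 log units; beyond the scatter) and that gap is large.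

The next compound is compound 4 `COc1cc(-n2cnc3ccc(-c4ccc(C(F)(F)F)cc4)cc32)cc(OC)c1OC` which carries trifluoromethyl in place of nitro on an aromatic carbon with the rest of the structure unchanged. For the measured compounds named here, no measured compound carries trifluoromethyl, so the evidence is indirect. Changing this outer group has given a 68-fold lower number from compound 1 to compound 2 (1.83 log units; beyond the scatter) as well as the large gap already noted, so a single swap here can matter greatly. Yet two quite different groups in compound 2 and compound 3 gave values within the scatter of each other. The one measured move away from nitro leads to compound 1 at 2970 nM and this makes a higher number the likelier direction, though only on thin evidence. The expected step is a 2.5-fold higher number from compound 3 to compound 4 (0.40 log units; beyond the scatter) which would be modest beside the large steps seen so far. Compound 4 is estimated at 200 nM with an expected range from 50 nM to 800 nM in this reading.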

Compound 4, half-maximal inhibitory concentration: 890 nM
Compound 4: the middle estimate sits 4.5-fold (0.65 log units) below what was measured; the measured number lies above the stated range.
By their numbers in this assay, from the lowest: compounds 2 and 3 (each within the scatter of the next); then compound 4; then compound 1.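

In this assay, trifluoromethyl turns out to be no stand-in for nitro at this aromatic carbon: there is an 11-fold higher number from compound 3 to compound 4 (1.05 log units; beyond the scatter) even though neither group carries a ring or a net charge, so two small groups can give clearly different results here. The result also adds a middle level to the series, with a 20-fold higher number from compound 2 to compound 4 (1.31 log units; beyond the scatter) on one side and a 3.3-fold lower number from compound 1 to compound 4 (0.52 log units; beyond the scatter) on the other, so that changes at this place now give three separate levels rather than the two seen before: compounds 2 and 3 together, then compound 4, then compound 1. Nitro and trifluoromethyl differ in their counted hydrogen-bond acceptors, but that is only a count, and no measurement shown here explains the step.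

Going by these compounds, it remains open whether any other group at this place, such as an amine, a nitrile or a carboxylic acid, could match compound 3. Also open, on these data alone, is how much the hydroxy and the methoxy of the 3-hydroxy-4-methoxyphenyl group in compound 2 each contribute when present alone.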